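Alkyl Groups on the Ring Amine Nitrogen and Cytotoxicity

The source may hold more compounds than are shown below. What is called first, only, known or untested is meant among the compounds shown, and "the series" means these compounds.

Compound 1, `N#Cc1ccc(Nc2nc(Oc3ccnc4ccccc34)nc(N3CCN(c4ccccc4Cl)CC3)n2)cc1C(F)(F)F`, gives in a functional assay on DU-145 cells (Homo sapiens) for cytotoxicity, read by sulforhodamine B assay, with a stated time of 48 h (a lower number here means that less compound is tolerated, a higher number that more compound is tolerated), only the limit > 100000 nM.
Compound 2, `CN1CCN(c2nc(Nc3ccc(C#N)c(C(F)(F)F)c3)nc(Oc3ccnc4ccccc34)n2)CC1`, gives in this assay only the limit > 100000 nM.
Compound 3, `CCN1CCN(c2nc(Nc3ccc(C#N)c(C(F)(F)F)c3)nc(Oc3ccnc4ccccc34)n2)CC1`, gives in this assay only the limit > 100000 nM.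

Compound 3 thus stands where every measured compound stands: at the limit of this assay, with no number resolved. The steps among the measured compounds are a step that the two limits leave unreadable from compound 1 to compound 2, a step that the two limits leave unreadable from compound 1 to compound 3, and a step that the two limits leave unreadable from compound 2 to compound 3; none of them can be read, since both ends sit at the limit (the limit of > 100000 nM in this assay, at which 3 of the 3 values shown sit).

The unmeasured compound 4, `CC(C)N1CCN(c2nc(Nc3ccc(C#N)c(C(F)(F)F)c3)nc(Oc3ccnc4ccccc34)n2)CC1`, differs from compound 3 by methyl in place of hydrogen on a saturated chain carbon bound to an amine nitrogen in a ring and a saturated chain carbon. Within the data shown here, the one measured step of the same kind, a step that the two limits leave unreadable from compound 2 to compound 3, and the two larger exchanges on the same ring amine nitrogen all left the compounds at the limit, so nothing in the data points to a change beyond the scatter in this assay for this further methyl.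

The expected step that the limit leaves unreadable from compound 3 to compound 4 is therefore flat, with compound 4 most likely again reported only as a limit. Compound 4 is estimated at 150000 nM, in the range from 100000 nM to 300000 nM.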

Compound 4, concentration lethal to 50% of the cells: > 100000 nM
Compound 4 was reported as a limit; the forecaster's own chance of this, stated with the estimate: 85%; the middle value lies beyond the limit too.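

No step from compound 1, compound 2 or compound 3 to compound 4 can be read in this assay, since compound 4 also gives only a limit: the limit of > 100000 nM in this assay, at which 4 of the 4 values shown sit.

The compounds shown leave open how far these four lie from one another, and whether any of the groups on the ring amine nitrogen changes the read-out at all.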